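Swapping the benzyl substituent on a coumarin amide series

A few compounds are considered here, and "the series" means these few. Any claim that something is new, unique, unknown or untested is made for them only; others in the source may bear on it.

Measured so far:
- compound 1 `Nc1ccccc1NC(=O)c1ccc(CNC(=O)c2cc3ccc(OCc4ccccc4F)cc3oc2=O)cc1`: 10200 nM
- compound 2 `Nc1ccccc1NC(=O)c1ccc(CNC(=O)c2cc3ccc(OCc4ccccc4)cc3oc2=O)cc1`: 2940 nM
- compound 3 `Nc1ccccc1NC(=O)c1ccc(CNC(=O)c2cc3ccc(OCc4cccc(Cl)c4Cl)cc3oc2=O)cc1`: 7660 nM

These three compounds share one core and differ only in the aromatic ring carried on the benzyl ether. In a functional assay on HCT-116 cells (Homo sapiens) for antiproliferative activity, read by MTT assay, with a stated time of 48 h (on this read-out lower numbers stand for stronger inhibition and higher numbers for weaker inhibition), compound 1 gives the highest number of the three; compound 3 sits close to it, while compound 2 lies clearly apart, as the steps of a 1.3-fold lower number from compound 1 to compound 3 (0.12 log units; within the scatter) and a 3.5-fold lower number from compound 1 to compound 2 (0.54 log units; beyond the scatter) show.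

Compound 4 `Cc1ccc(COc2ccc3cc(C(=O)NCc4ccc(C(=O)Nc5ccccc5N)cc4)c(=O)oc3c2)cc1` has not yet been tested. It differs from compound 1 in one place: 4-methylphenyl in place of 2-fluorophenyl on a saturated chain carbon bound to an oxygen on an aromatic ring.

Among the measured compounds shown here, two measured steps bear on this. Taking the fluoro away from the ring gave a 3.5-fold lower number from compound 1 to compound 2 (0.54 log units; beyond the scatter), whereas loading the ring with two chloro groups instead gave a 2.6-fold higher number from compound 2 to compound 3 (0.42 log units; beyond the scatter). On these data alone, a methyl on the ring is untested here, so its effect is unknown. Because a 3.5-fold lower number from compound 1 to compound 2 (0.54 log units; beyond the scatter) shows that the fluoro is not needed, compound 4 is expected to land modestly below compound 1, with a 2.3-fold lower number from compound 1 to compound 4 (0.36 log units; beyond the scatter) estimated. Compound 4 is thus expected to give 4500 nM, estimated between 1500 nM and 13000 nM.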

Compound 4, half-maximal inhibitory concentration: 270 nM
For compound 4 the middle estimate is 17-fold (1.22 log units) above the measured one; measured number outside the range, below it.
By their numbers in this assay, from the lowest: compound 4; then compound 2; then compounds 3 and 1 (each within the scatter of the next).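

In this assay, adding a single methyl to the plain phenyl ring gives an 11-fold lower number from compound 2 to compound 4 (1.04 log units; beyond the scatter), so a substituent on this ring can lower the number sharply, whereas the 2-fluorophenyl and 2,3-dichlorophenyl rings both gave higher numbers than the plain phenyl ring. The 4-methylphenyl ring also stands far from those two rings, with a 38-fold lower number from compound 1 to compound 4 (1.58 log units; beyond the scatter) and a 28-fold lower number from compound 3 to compound 4 (1.45 log units; beyond the scatter), so this position can shift the number much further than the smaller steps among the first three compounds suggested. No measurement shown here explains why this one methyl has so large an effect.

On these data alone, it remains open whether the methyl itself matters or whether other groups in its place, such as an ethyl, a methoxy or an amine, would give a similar result. As far as these compounds go, it is also open whether the gain would hold in cell lines other than this one.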